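Dimethylphenyl isomers on the shared core

The compounds below may be only part of what the source reports. "The series", "measured", "known", "first", "only" and "open" are said of these compounds alone.

Among the compounds with values here, in a functional assay on KB cells (Homo sapiens) for antiproliferative activity, read by sulforhodamine B assay, with a stated time of 3 days (a lower number here means that less compound is needed, a higher number that more compound is needed for the effect), compound 1 (`CCC1=C(O)c2c(oc(-c3ccc(CC)cc3)cc2=O)C(CC)(CC)C1=O`) gives 21.9 uM and compound 2 (`CCC1=C(O)c2c(oc(-c3cccc(C)c3C)cc2=O)C(CC)(CC)C1=O`) gives 3.1 uM, so compound 2 holds the lower of the two numbers so far. Compound 3 (`CCC1=C(O)c2c(oc(-c3cc(C)ccc3C)cc2=O)C(CC)(CC)C1=O`) carries 2,5-dimethylphenyl in place of 2,3-dimethylphenyl on an aromatic carbon, next to the ring oxygen of the shared core: 2,5-dimethylphenyl in place of 2,3-dimethylphenyl on an aromatic carbon.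

Within the data shown here, only one measured step bears on this place. It replaced 4-ethylphenyl with 2,3-dimethylphenyl, and it is modest and beyond the scatter: a 7.1-fold lower number from compound 1 to compound 2 (0.85 log units; beyond the scatter). That step shows that the number in this assay can respond to a change of group here. Among the measured compounds shown here, it does not show what happens when the group keeps its atoms and only their arrangement differs, and no measured pair isolates that change. A smaller step is therefore expected, with no firm direction and none clearly beyond the scatter, starting from compound 2 at 3.1 uM. The expected change is a 1.3-fold higher number from compound 2 to compound 3 (0.11 log units; within the scatter). For compound 3 the estimated value in this assay is 4 uM, with an expected range from 1.5 uM to 11 uM.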

Compound 3, concentration for half-maximal effect: 14.5 uM
Beside the measured number, compound 3's estimate is 3.6-fold (0.56 log units) below it; the whole stated range lies below it.
By their numbers in this assay, from the lowest: compound 2; then compounds 3 and 1 (each within the scatter of the next).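

Keeping the atoms of the group and changing only their arrangement is enough to move the number in this assay, with a 4.7-fold higher number from compound 2 to compound 3 (0.67 log units; beyond the scatter) for the swap of 2,3-dimethylphenyl for 2,5-dimethylphenyl, so this position responds to the placement of the two methyl groups and not only to a change of group, as the step from 4-ethylphenyl had shown. Set against 4-ethylphenyl, 2,5-dimethylphenyl gives a 1.5-fold lower number from compound 1 to compound 3 (0.18 log units; within the scatter) and so cannot be told apart from it, which leaves 2,3-dimethylphenyl as the only one of the three groups whose steps to both others are printed as beyond the scatter. No measurement at hand accounts for the gap between the two isomers.

Three groups at one position cannot show whether the result for 2,3-dimethylphenyl depends on having both methyl groups, or whether it would hold for a single methyl group or an unsubstituted phenyl ring. As far as these compounds go, it also stays open how this position would respond to a phenyl ring carrying a methoxy group, an amine or a carboxylic acid, and whether the gap between the isomers holds on other variants of the shared core.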